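The source may hold more compounds than are shown below. What is called first, only, known or untested is meant among the compounds shown, and "the series" means these compounds.

The series rests on a shared core, seen in compound 1 `Cc1cnc(Nc2ccc(Cl)cc2)nc1Nc1nc2ccccc2s1`, compound 2 `NS(=O)(=O)c1ccc(Nc2nccc(Nc3nc4ccc(F)cc4s3)n2)cc1` and compound 3 `COc1ccc2nc(Nc3ccnc(Nc4ccc(S(C)(=O)=O)cc4)n3)sc2c1`, and is judged in a functional assay on MCF7 cells (Homo sapiens) for antiproliferative activity, read by MTT assay, with a stated time of 48 h; a lower number here means a stronger inhibitor, a higher number a weaker inhibitor. Compound 1 gives only a limit of > 50000 nM in this assay. Compound 3 likewise reaches only a limit, > 50000 nM. Among the compounds with values here, compound 2 is the single compound with a measured number, 10900 nM, and therefore stands alone as the reference point of the set, with the other two values sitting at the limit of > 50000 nM in this assay, at which 2 of the 3 values shown sit.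

Compound 4 `Cc1ccc2nc(Nc3ccnc(Nc4ccc(S(N)(=O)=O)cc4)n3)sc2c1` is not yet measured. It differs from compound 2 by methyl in place of fluoro on an aromatic carbon. Within the data shown here, no measured pair in the set differs in one place, so the size of this step cannot be read from the data. The expected step of a 1.4-fold higher number from compound 2 to compound 4 (0.14 log units; within the scatter) is taken to lie within the usual scatter, with no clear direction. Compound 4 is accordingly estimated at 15000 nM, within a range from 5000 nM to 50000 nM.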

Compound 4, half-maximal inhibitory concentration: 5740 nM
Estimate against measurement, compound 4: 2.6-fold (0.42 log units) above; the measured number falls inside the stated range.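

The pair gives the series its first step in one place: in this assay, methyl in place of fluoro on an aromatic carbon gives a 1.9-fold lower number from compound 2 to compound 4 (0.28 log units; within the scatter). This position, on the six-membered aromatic ring of carbon only, therefore takes either group with no change that can be told from the scatter, and the two compounds stand level. Both groups here go with a measured number, not a limit.

The compounds shown speak for fluoro and methyl alone at this position, so what an amine, a carboxylic acid or a longer chain there would do stays open. The remaining compounds add no further step to set beside this one, and their values are limits, not numbers: the limit of > 50000 nM in this assay, at which 2 of the 4 values shown sit.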